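A few compounds are considered here, and "the series" means these few. Any claim that something is new, unique, unknown or untested is made for them only; others in the source may bear on it.

Measured compounds:
compound 1 `CCOc1ccc(-n2c(S)nnc2CSc2nnc(-c3ccccc3)n2-c2ccccc2)cc1`, "not determined" (no result reported)
compound 2 `Sc1nnc(Sc2nnc(-c3ccccc3)n2-c2ccccc2)n1-c1ccc(Cl)cc1`, 49700 nM

Compound 1 `CCOc1ccc(-n2c(S)nnc2CSc2nnc(-c3ccccc3)n2-c2ccccc2)cc1` was entered into a functional assay on MDA-MB-231 cells (Homo sapiens) for inhibition, read by MTT assay, with a stated time of 48 h (a lower number here means a stronger inhibitor, a higher number a weaker inhibitor), yet for compound 1 the record reads "not determined" (no result reported), so no number fixes where it stands. For the measured compounds named here, the only figure belongs to compound 2 `Sc1nnc(Sc2nnc(-c3ccccc3)n2-c2ccccc2)n1-c1ccc(Cl)cc1`, which shares the core of compound 1; in this assay compound 2 gives 49700 nM, a weak inhibitor. The account follows the step from compound 1 to compound 3 `COc1ccc(-n2c(S)nnc2CSc2nnc(-c3ccccc3)n2-c2ccccc2)cc1`. The change is hydrogen in place of methyl on a saturated chain carbon bound to an oxygen on an aromatic ring. With no number for compound 1, no step can be read; a change of this small size is expected to move this assay little, if at all beyond the scatter. Because compound 2 gives 49700 nM in this assay, compound 3 is expected to be a weak inhibitor too, estimated at 40000 nM, within 10000 nM to 150000 nM.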

Compound 3, half-maximal inhibitory concentration: 29200 nM
The estimate for compound 3 lay 1.4-fold (0.14 log units) above the measured number, within the range that was stated.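

Compound 1 has no number to set against compound 3, and the step between them cannot be read. The compounds shown leave open what going from 4-ethoxyphenyl to 4-methoxyphenyl does to this inhibition. No supporting measurement bears on this result.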